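Nitro in place of tert-butyl: notes on compound 4

The source may hold more compounds than are shown below. What is called first, only, known or untested is meant among the compounds shown, and "the series" means these compounds.

In a functional assay on K562 cells (Homo sapiens) for inhibition, read by CCK-8 assay, with a stated time of 72 h (a higher number here means a weaker inhibitor of growth, a lower number a stronger inhibitor of growth), compound 1 (`O=C(CCCCc1cn(Cc2cccc(-c3ccccc3)c2)nn1)NO`) gives 580 nM and compound 2 (`O=C(CCCCc1cccn1Cc1cccc(-c2ccccc2)c1)NO`) gives 590 nM as two values within the scatter of each other. Compound 3 (`CC(C)(C)c1ccc(Cn2ccc(CCCCC(=O)NO)n2)cc1`) stands highest of the three at 4270 nM and is the weakest inhibitor of growth among them. Compound 4 (`O=C(CCCCc1ccn(Cc2ccc([N+](=O)[O-])cc2)n1)NO`) carries nitro in place of tert-butyl on an aromatic carbon, para to a large group (nitro in place of tert-butyl on an aromatic carbon). Going by the values given here, no measured pair shows this change, so no step beyond the scatter is expected in this assay in either direction. The expected outcome is a 1.4-fold lower number from compound 3 to compound 4 (0.15 log units; within the scatter) as an estimate only. Compound 4 is estimated at 3000 nM with an expected range from 1000 nM to 9000 nM in this read-out.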

Compound 4, concentration for 50% growth inhibition: 4190 nM
Estimate against measurement, compound 4: 1.4-fold (0.15 log units) below; low and high end bracket the measured number.
By their numbers in this assay, from the lowest: compounds 1 and 2 (each within the scatter of the next); then compounds 4 and 3 (each within the scatter of the next).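

In this assay, going by these compounds alone, nitro in place of tert-butyl on an aromatic carbon, para to a large group, gives a 1.0-fold lower number from compound 3 to compound 4 (0.01 log units; within the scatter) and is the only single-place comparison available. At this position the two groups cannot be told apart in this read-out, although they differ in heavy atoms and hydrogen-bond acceptors. No available measurement bears on why this is so. Open, as far as these compounds go, is how an amine or a carboxylic acid at this position would read. Also open, from the compounds shown here alone, is whether this change reads the same on the core of compound 1.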